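Amine rearrangement on the aminodiol chain: compound 3 to compound 4

The source may hold more compounds than are shown below. What is called first, only, known or untested is meant among the compounds shown, and "the series" means these compounds.

Three members of the series have numbers in an ADME assay on cells (Splenocyte, Mus musculus, strain BALB/c) for cytotoxicity, read by MTT assay, tested at 10 ug/mL; a lower number here means a weaker effect, a higher number a stronger effect of the compound at the concentration tested. Compound 1 `CCCCCCCCCCCCCCC(CO)NC(=O)CCCC(=O)OC` gives 18.9%. Compound 2 `CCCCCCCCCCCCCCC(CO)NC(=O)CCCC(=O)O` gives 14.5%, and compound 3 `CCCCCCCCCCCCCCC(CO)N(CC)CC` gives 12.8%. On these numbers compound 3 stands lowest of the three, yet its gaps to compound 2 and to compound 1 both lie within the scatter, so no order among the three can be read from them.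

Among the compounds with values here, the only one-place step measured so far is a number 4.4 percentage points lower from compound 1 to compound 2 (within the scatter), a change at the ester end of the chain that stays within the scatter. It does not touch the amine.

Compound 4 `CCCCCCCCCCCCCCC(CO)NCCCC` has not been measured in this assay. It differs from compound 3 by butylamino in place of diethylamino on a saturated chain carbon bound to two saturated chain carbons; the two hold the same atoms, joined differently. Within the data shown here, no measured step concerns a rearrangement at this position, and the one step that is known was within the scatter, so nothing in the data points to a move beyond the scatter in this assay, in either direction.

For compound 4 the expected value in this assay is therefore 14%, with a range of 6% to 24%. The expected step is a number 1.2 percentage points higher from compound 3 to compound 4 (within the scatter), none beyond the scatter.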

Compound 4, a percentage reported as activity, at one concentration (the size of the read-out at that concentration, not a potency): 16.4%
Compound 4: the middle estimate sits 2.4 percentage points below what was measured; low and high end bracket the measured number.
By their numbers in this assay, from the lowest: compounds 3, 2, 4 and 1 (each within the scatter of the next).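

Working notes on the amine position: in this assay, butylamino in place of diethylamino on a saturated chain carbon bound to two saturated chain carbons gives a number 3.6 percentage points higher from compound 3 to compound 4 (within the scatter), the first measured change at this position. Within the data shown here, the same atoms joined differently, with 1 hydrogen-bond donor in butylamino against 0 in diethylamino, therefore produce no step that can be told from the scatter. On the amine nitrogen, butyl in place of (3-carboxypropyl)carbonyl gives a number 1.9 percentage points higher from compound 2 to compound 4 (within the scatter) and butyl in place of (3-(methoxycarbonyl)propyl)carbonyl gives a number 2.5 percentage points lower from compound 1 to compound 4 (within the scatter), so neither replacement separates from the scatter either, and nothing on hand gives a reason for any of these steps.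

Still open, as far as these compounds go, is whether a free primary amine, a longer chain on the nitrogen such as octyl, or a piperidine ring at this place would give a step beyond the scatter in this assay. A shorter main chain is also open, since all the compounds shown carry the same long chain, and so is the response at other concentrations.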